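The source may hold more compounds than are shown below. What is called first, only, known or untested is meant among the compounds shown, and "the series" means these compounds.

Measured compounds in a functional assay on A549 cells (Homo sapiens) for cytotoxicity, read by MTT assay; a lower number here means a stronger inhibitor, a higher number a weaker inhibitor:
- Compound 1 `CC1=NNC(=O)C1C(c1c(-c2ccccc2)[nH]c2ccc(C)cc12)c1c(-c2ccccc2)[nH]c2ccc(Cl)cc12`: 35000 nM
- Compound 2 `CC1=NNC(=O)C1C(c1c(-c2ccccc2)[nH]c2ccccc12)c1c(-c2ccccc2)[nH]c2ccc(C)cc12`: 22100 nM
- Compound 3 `COc1ccc2[nH]c(-c3ccccc3)c(C(c3c(-c4ccccc4)[nH]c4ccc(Cl)cc34)C3C(=O)NN=C3C)c2c1`: 1100 nM

Among these three, compound 3 shows the lowest number, and its gaps to compound 1 and to compound 2 both lie beyond the usual scatter of this assay. Compound 4 `CC1=NNC(=O)C1C(c1c(-c2ccccc2)[nH]c2ccccc12)c1c(-c2ccccc2)[nH]c2ccc(Cl)cc12` is not yet measured. It differs from compound 3 in one place: hydrogen in place of methoxy on an aromatic carbon.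

Going by the values given here, two measured steps bear on this change. The step of a 32-fold lower number from compound 1 to compound 3 (1.50 log units; beyond the scatter) shows that the methoxy group goes with the strongest inhibition seen here. The step of a 1.6-fold lower number from compound 1 to compound 2 (0.20 log units; within the scatter) shows that swapping chloro for hydrogen at the other end of the shared core changes little. Among the compounds with values here, no pair measured so far compares hydrogen directly with methoxy, so the size of the coming step rests on the methyl-containing compounds. Removing the methoxy is expected to give up most of the gain seen in compound 3, so the step of an 18-fold higher number from compound 3 to compound 4 (1.26 log units; beyond the scatter) is expected to raise the number well beyond the scatter. Compound 4 is estimated at 20000 nM, with a range from 4000 nM to 80000 nM.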

Compound 4, half-maximal inhibitory concentration: 31300 nM
The estimate for compound 4 lay 1.6-fold (0.19 log units) below the measured number, and the stated range covers the measured number.
By their numbers in this assay, from the lowest: compound 3; then compounds 2, 4 and 1 (each within the scatter of the next).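

In this assay, hydrogen and methoxy can now be compared directly at this position, and a 28-fold higher number from compound 3 to compound 4 (1.45 log units; beyond the scatter) shows that the low number of compound 3 does not survive the loss of methoxy. The step for hydrogen in place of methyl at the same position is a 1.1-fold lower number from compound 1 to compound 4 (0.05 log units; within the scatter) and stays within the scatter, so among hydrogen, methyl and methoxy, only methoxy stands apart, with chloro on the other side of the shared core. Chloro and methyl also cannot be told apart in the step of a 1.4-fold higher number from compound 2 to compound 4 (0.15 log units; within the scatter) when hydrogen is the partner group.

No measurement shown explains why methoxy differs from methyl here. On these data alone, whether hydroxyl, ethoxy or an amine at this position would match methoxy remains open, as does whether methoxy would hold its effect without the chloro.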